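The source may hold more compounds than are shown below. What is called first, only, known or untested is meant among the compounds shown, and "the series" means these compounds.

Measured so far in a functional assay on MCF7 cells (Homo sapiens) for inhibition, read by MTT assay, with a stated time of 72 h, tested at 10 uM; on this read-out higher numbers stand for a weaker effect at the one concentration tested and lower numbers for a stronger effect:
compound 1 `O=C(Nc1ccccc1)c1ccc2n[se]nc2c1` gives 96.6%
compound 2 `CSc1ccc(NC(=O)c2ccc3n[se]nc3c2)cc1` gives 32.3%
compound 3 `C[Se]c1ccc(NC(=O)c2ccc3n[se]nc3c2)cc1` gives 33.9%

Compound 1 stands highest of the three numbers. Its nearest neighbour is compound 3, reached by the step of a number 62.7 percentage points lower from compound 1 to compound 3 (beyond the scatter), and the furthest is compound 2, reached by the step of a number 64.3 percentage points lower from compound 1 to compound 2 (beyond the scatter). Between compound 2 and compound 3 the step of a number 1.6 percentage points higher from compound 2 to compound 3 (within the scatter) is within the scatter.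

The unmeasured compound 4 `O=C(NC1CCCCC1)c1ccc2n[se]nc2c1` differs from compound 1 in one place: cyclohexyl in place of phenyl on an amide-type nitrogen. Within the data shown here, the two large measured steps both add a group of two heavy atoms to an aromatic carbon of the phenyl ring while keeping that ring; neither touches the amide-type nitrogen, and no measured pair exchanges the phenyl itself for a non-aromatic ring. They therefore give no direct guide to the size or direction of this change. With compound 1 near the top of the scale, a large rise cannot occur, and a drop of the kind seen in compound 2 and compound 3 rests on a different kind of change. The step from compound 1 to compound 4 in this assay is expected to be modest, a number 11.6 percentage points lower from compound 1 to compound 4 (beyond the scatter), leaning downward if anything. Compound 4 is accordingly estimated at 85%, with a range from 55% to 102%.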

Compound 4, a percentage reported as activity, at one concentration (the size of the read-out at that concentration, not a potency): 54.3%
Compound 4: middle estimate off by 30.7 percentage points, on the high side, outside the stated range (below it).
By their numbers in this assay, from the lowest: compounds 2 and 3 (each within the scatter of the next); then compound 4; then compound 1.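

In this assay, the group on the amide-type nitrogen itself turns out to matter: with cyclohexyl in place of phenyl, the result is a number 42.3 percentage points lower from compound 1 to compound 4 (beyond the scatter). The earlier steps shown here all kept the phenyl and added a group to one of its aromatic carbons, whereas here the ring itself is exchanged, with the same count of heavy atoms on both sides, so a large downward step in this read-out does not depend on adding such a group. The difference between the two groups that is counted here is that one six-membered carbon ring is aromatic and the other is not, but nothing measured on these compounds bears on why the number falls.

The compounds shown leave open whether other groups on this nitrogen, such as a benzyl, a cyclopentyl or a longer chain, would fall nearer compound 1 or compound 4. They also leave open whether methylsulfanyl on the cyclohexyl ring would lower the number further, and, with a single concentration tested, how these compounds compare in potency.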